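Working notes: fluoro in place of methoxy in compound 2

The compounds below may be only part of what the source reports. "The series", "measured", "known", "first", "only" and "open" are said of these compounds alone.

Measured in a functional assay on A549 cells (Homo sapiens) for antiproliferative activity, read by sulforhodamine B assay, with a stated time of 48 h; a lower number here means a stronger inhibitor, a higher number a weaker inhibitor:
- compound 1 `COc1cccc(C=C(C(=O)/C=C/c2cccc(OC)c2OC)C(=O)/C=C/c2cccc(OC)c2OC)c1OC`: 320 nM
- compound 2 `COc1cc(OC)c(/C=C/C(=O)C(=Cc2ccc(O)c(OC)c2)C(=O)/C=C/c2c(OC)cc(OC)cc2OC)c(OC)c1`: 580 nM

Going by the values given here, with only two values, compound 2 at 580 nM lies within the usual scatter of compound 1 at 320 nM, so the two cannot be ranked on these numbers.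

The next compound to be read is compound 3 `COc1cc(OC)c(/C=C/C(=O)C(=Cc2ccc(O)c(F)c2)C(=O)/C=C/c2c(OC)cc(OC)cc2OC)c(OC)c1`, which departs from compound 2 in one place: fluoro in place of methoxy on an aromatic carbon. The site of this change is ortho to a hydroxy group and meta to a large group, and the change turns 4-hydroxy-3-methoxyphenyl into 3-fluoro-4-hydroxyphenyl.

Among the compounds with values here, no measured pair shows this change, so its size in this assay has no direct precedent here. Within the data shown here, the only anchor is compound 2 at 580 nM, and no shift in either direction beyond the scatter is expected. The expected size is a 1.1-fold higher number from compound 2 to compound 3 (0.05 log units; within the scatter), an estimate that stays within the scatter. For compound 3 the estimated value is 650 nM, with an expected range from 220 nM to 1900 nM.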

Compound 3, half-maximal inhibitory concentration: 1060 nM
Compound 3: middle estimate off by 1.6-fold (0.21 log units), on the low side; the range from low to high includes it.
By their numbers in this assay, from the lowest: compounds 1, 2 and 3 (each within the scatter of the next, the first and the last beyond it).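

Going by these compounds alone, compound 3 gives the first reading of this change: in this assay, going from 4-hydroxy-3-methoxyphenyl to 3-fluoro-4-hydroxyphenyl brings a 1.8-fold higher number from compound 2 to compound 3 (0.26 log units; within the scatter) and so the two compounds cannot be ranked. At this site, ortho to a hydroxy group and meta to a large group, methoxy with its 2 heavy atoms and 1 hydrogen-bond acceptor can thus give way to fluoro with 1 heavy atom and 0 hydrogen-bond acceptors without a step beyond the scatter, though this single pair cannot exclude a real shift of a size hidden within that scatter. No measurement is available that would explain the size of this step.

On these data alone, whether chloro, trifluoromethyl or an amine at the same site would move the number beyond the scatter remains open, as does the part played by the neighbouring hydroxy group, which stays in place in both compounds. Also open, as far as these compounds go, is whether fluoro in place of methoxy would read the same way on the two trimethoxyphenyl-bearing arms of the shared core.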